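Benzofuran in Place of Methoxyphenoxy on a Shared Core

The compounds below may be only part of what the source reports. "The series", "measured", "known", "first", "only" and "open" are said of these compounds alone.

Compound 1 `Cc1ccccc1-n1nc(C)c2c1NC(=O)[C@H](C)S[C@@H]2c1ccc(-c2ccc(C(=O)O)cc2)cc1`: in an assay on isolated protein for agonist activity at Bile acid receptor (Homo sapiens), read by AlphaScreen, with a stated time of 30 min (a lower number here means that less compound is needed, a higher number that more compound is needed for the effect), compound 1 gives "not active" (no number reported).
Compound 2 `COc1cccc(Oc2ccc([C@H]3S[C@@H](C)C(=O)Nc4c3c(C)nn4-c3ccccc3C)cc2)c1`: in this assay compound 2 gives 1700 nM.
Compound 3 `COc1ccccc1Oc1ccc([C@H]2S[C@@H](C)C(=O)Nc3c2c(C)nn3-c2ccccc2C)cc1`: in this assay compound 3 gives 1700 nM.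

Compound 3 stands level with compound 2, the step of no change at the digits printed from compound 2 to compound 3 (within the scatter) lying within the scatter; compound 1 has no number. Compound 4 `Cc1ccccc1-n1nc(C)c2c1NC(=O)[C@H](C)S[C@@H]2c1ccc(-c2cc3ccccc3o2)cc1` differs from compound 3 by 1-benzofuran-2-yl in place of 2-methoxyphenoxy on an aromatic carbon. Among the measured compounds shown here, no measured step swaps an oxygen-linked ring for a directly attached bicyclic group, so the one step in hand, no change at the digits printed from compound 2 to compound 3 (within the scatter), bears only loosely on it, and compound 1 gives no number to compare. Compound 4 is therefore expected near compound 3, with a wide range and no direction favoured, the expected step being a 1.2-fold higher number from compound 3 to compound 4 (0.07 log units; within the scatter). Compound 4 is estimated at 2000 nM, between 500 nM and 10000 nM.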

Compound 4, half-maximal effective concentration: 1500 nM
For compound 4 the middle estimate is 1.3-fold (0.12 log units) above the measured one, and the stated range covers the measured number.
By their numbers in this assay, from the lowest: compounds 4, 2 and 3 (each within the scatter of the next).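

In this assay, the aromatic carbon para to a large group accepts a directly attached 1-benzofuran-2-yl in place of either methoxyphenoxy group, as the two steps show (a 1.1-fold lower number from compound 3 to compound 4 (0.05 log units; within the scatter)) and (a 1.1-fold lower number from compound 2 to compound 4 (0.05 log units; within the scatter)). Among these compounds, then, neither the oxygen link nor the methoxy is needed to hold the number at this level, whereas the earlier pair had varied only where the methoxy sat. No evidence here explains this result. Going by these compounds, whether an amine on the benzofuran or a longer chain at this position would shift the number remains open.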